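The source may hold more compounds than are shown below. What is called first, only, known or untested is meant among the compounds shown, and "the series" means these compounds.

Compound 1 `COc1ccc(N(C)c2nc(C)nc3ccccc23)cc1C(=O)OCCC[Se]C#N` gives 340 nM in a functional assay on HepG2 cells (Homo sapiens) for inhibition, read by MTT assay, with a stated time of 48 h (a lower number here means a stronger inhibitor, a higher number a weaker inhibitor), the lower of the two numbers measured. Compound 2 `COc1ccc(N(C)c2nc(C)nc3ccccc23)cc1C(=O)OCCCCC[Se]C#N` gives 667 nM; the step of a 2.0-fold higher number from compound 1 to compound 2 (0.29 log units; within the scatter) is a lengthening of the chain that carries the selenium. Compound 3 `COc1ccc(N(C)c2nc(C)nc3ccccc23)cc1[Se]C` differs from compound 1 by a group of 2 heavy atoms (1 carbon, 1 selenium; no ring) in place of a group of 9 heavy atoms (5 carbon, 1 nitrogen, 2 oxygen, 1 selenium; no ring), on an aromatic carbon. For the measured compounds named here, no measured step changes this part of the molecule, so the only known step gives little guidance. Compound 3 is expected to show a 4.4-fold higher number from compound 1 to compound 3 (0.64 log units; beyond the scatter), and its estimated value is 1500 nM, within a range of 300 nM to 8000 nM.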

Compound 3, half-maximal inhibitory concentration: 17 nM
The estimate for compound 3 lay 88-fold (1.95 log units) above the measured number; measured number below the stated range.
By their numbers in this assay, from the lowest: compound 3; then compounds 1 and 2 (each within the scatter of the next).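

In this assay the swap on this aromatic carbon gives a 20-fold lower number from compound 1 to compound 3 (1.30 log units; beyond the scatter) and so counts for far more than the chain lengthening did: a large group is not needed here for a low number. The step removes the carbonyl and the nitrile at once and also brings the selenium onto the ring, so the data cannot say which of these changes matters. Nothing available gives a reason for the drop. From the compounds shown here alone, it remains open whether selenium is needed at all, which a plain ethyl group on this carbon would test. Also open, going by these compounds, is whether a longer chain on the selenium would keep the number this low.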